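Acetamido for acetoxy on two triazole-bearing cores

The compounds below may be only part of what the source reports. "The series", "measured", "known", "first", "only" and "open" are said of these compounds alone.

Compound 1 `CC(=O)OC[C@H]1O[C@@H](n2cc(CCl)nn2)[C@H](OC(C)=O)[C@@H](OC(C)=O)[C@@H]1OC(C)=O` gives 37 ug/mL in a functional assay on HeLa cells (Homo sapiens), read by colorimetric assay, with a stated time of 72 h; a lower number here means that less compound is needed, a higher number that more compound is needed for the effect. Compound 2 `CC(=O)N[C@@H]1[C@@H](OC(C)=O)[C@H](OC(C)=O)[C@@H](COC(C)=O)O[C@H]1n1cc(CCl)nn1` gives 20 ug/mL in this assay. The difference between them is acetamido in place of acetoxy on a saturated ring carbon, and the step is a 1.9-fold lower number from compound 1 to compound 2 (0.27 log units; within the scatter).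

Compound 3 `CC(=O)OC[C@H]1O[C@@H](n2nnc(CO)c2CO)[C@H](OC(C)=O)[C@@H](OC(C)=O)[C@@H]1OC(C)=O` returns only a limit of the assay in this assay, > 100 ug/mL. The two cores differ by 4,5-bis(hydroxymethyl)-1H-1,2,3-triazol-1-yl in place of 4-(chloromethyl)-1H-1,2,3-triazol-1-yl on a saturated ring carbon, and this step is an at least 2.7-fold higher number from compound 1 to compound 3 (0.43 log units; beyond the scatter); the result for compound 3 sits at the limit of > 100 ug/mL in this assay, at which 1 of the 3 values shown sits.

Compound 4 `CC(=O)N[C@@H]1[C@@H](OC(C)=O)[C@H](OC(C)=O)[C@@H](COC(C)=O)O[C@H]1n1nnc(CO)c1CO` is not yet measured. It differs from compound 3 by acetamido in place of acetoxy on a saturated ring carbon. For the measured compounds named here, this is the same kind of change as the one from compound 1 to compound 2, though the surroundings are not the same word for word: in compound 1 the carbon is next to the ring atom that bears a 4-(chloromethyl)-1H-1,2,3-triazol-1-yl group, whereas in compound 3 it is next to the ring atom that bears a 4,5-bis(hydroxymethyl)-1H-1,2,3-triazol-1-yl group.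

The step expected from compound 3 to compound 4 in this assay is an at least 1.1-fold lower number from compound 3 to compound 4 (0.04 log units; that floor lies within the scatter), set beside a 1.9-fold lower number from compound 1 to compound 2 (0.27 log units; within the scatter), which stayed within the scatter. The expectation rests on compound 3 being known only as a limit, > 100 ug/mL, so a step of the earlier size would leave compound 4 near that limit. Compound 4 is estimated at 90 ug/mL in this assay, with a range from 45 ug/mL to 250 ug/mL, and a good chance that only a limit is reported again.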

Compound 4, concentration for half-maximal effect: > 100 ug/mL
Compound 4 was reported as a limit (the forecaster's own chance of this, stated with the estimate: 55%); middle value at least 1.1-fold (0.04 log units) from the limit.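

Compound 3 and compound 4 are both known only as limits in this assay, so the step for acetamido in place of acetoxy cannot be read on the core bearing the 4,5-bis(hydroxymethyl)-1H-1,2,3-triazol-1-yl group, and the readings there stop at a single limit: the limit of > 100 ug/mL in this assay, at which 2 of the 4 values shown sit. It is not shown whether that change carries over from the core of compound 1, where the only readable instance is a 1.9-fold lower number from compound 1 to compound 2 (0.27 log units; within the scatter). The change that can be followed on both cores is 4,5-bis(hydroxymethyl)-1H-1,2,3-triazol-1-yl in place of 4-(chloromethyl)-1H-1,2,3-triazol-1-yl, which goes the same way on the acetamido core with an at least 5.0-fold higher number from compound 2 to compound 4 (0.69 log units; beyond the scatter), though the two sizes cannot be ranked: the same change on two cores in this assay, an at least 2.7-fold higher number (0.43 log units; beyond the scatter) from compound 1 to compound 3 and an at least 5.0-fold higher number (0.69 log units; beyond the scatter) from compound 2 to compound 4; the limit leaves it open whether they differ.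

The compounds shown leave open where compound 3 and compound 4 truly stand, and whether acetamido in place of acetoxy has a readable effect on any triazole other than the 4-(chloromethyl) one. A triazole carrying an aminomethyl group, a carboxylic acid or a longer chloroalkyl chain, set on both the acetoxy and the acetamido cores, would give further pairs for that comparison.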